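Weak Modulators: From a Methyl Ester to a Fluorinated Acid

A few compounds are considered here, and "the series" means these few. Any claim that something is new, unique, unknown or untested is made for them only; others in the source may bear on it.

Compound 1, `Cc1c(OCCCCOc2ccc(C(=O)O)cc2)ccc(C(=O)CC2CCCC2)c1O`: > 10000 nM
Compound 2, `Cc1cc(C(=O)O)ccc1OCCCCOc1ccc(C(=O)CC(C)C)c(O)c1C`: 1850 nM
Compound 3, `COC(=O)c1ccc(OCCCCOc2ccc(C(=O)CC3CCCC3)c(O)c2C)cc1`: "not determined" (no result reported)

Three compounds have been examined in an assay on HEK293 cells for positive allosteric modulation of metabotropic glutamate receptor 3 (Rattus norvegicus), read by thallium flux, with a stated time of 2.5 min; a higher number here means that more compound is needed for the effect, a lower number that less compound is needed. For compound 1 the result is not a number but a limit of the assay, > 10000 nM. That entry for compound 1 is the limit of > 10000 nM in this assay, at which 1 of the 3 values shown sits. Compound 2 gives 1850 nM in this assay. Compound 3 stands apart from both: no result was reported for it, "not determined" (no result reported), so it has no place among the numbers and offers no starting point for a measured step.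

The change from compound 3 to compound 4, `Cc1c(OCCCCOc2ccc(C(=O)O)cc2F)ccc(C(=O)CC2CCCC2)c1O`, is 4-carboxy-2-fluorophenyl in place of 4-(methoxycarbonyl)phenyl on an oxygen on a saturated carbon. Since compound 3 carries no value, no step size in this assay can be anchored to it, and the expectation for compound 4 has to rest on what the other compounds show. Compound 4 shares most of its structure with compound 1, and the result for compound 1 was a limit, > 10000 nM. Compound 2 shows that a carboxylic acid on this scaffold can give a measurable number, 1850 nM. Compound 4 is therefore expected to be weak, with about 8000 nM and a plausible range from 2000 nM to 30000 nM, and a fair chance that only a limit is reported.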

Compound 4, half-maximal effective concentration: > 10000 nM
Compound 4 gave a limit, no number; the forecaster's own chance of this, stated with the estimate: 55%; middle value at least 1.2-fold (0.09 log units) from the limit.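

Compound 1 and compound 4 both give a limit rather than a number, so no step between them can be read in this assay: the limit of > 10000 nM in this assay, at which 2 of the 4 values shown sit.

From the compounds shown here alone, whether fluoro in place of hydrogen on an aromatic carbon changes the concentration needed for the effect, and in which direction, stays open.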